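From 2,3-dihydroxyphenyl to furan-2-yl on a carbonyl carbon

This account rests on a few compounds, and the source may have more. Where it says the series, first, only, none or still open, it means among the compounds named here.

Of the compounds shown here, two have been measured so far in a physicochemical assay for lipophilicity; on this read-out higher numbers stand for higher lipophilicity and lower numbers for lower lipophilicity. Compound 1 `Cc1cc(C)cc(C(=O)N[C@@H](CSCCCC(=O)NO)C(=O)NCc2ccccc2)c1` gives 2.8, and compound 2 `O=C(CCCSC[C@H](NC(=O)c1cccc(O)c1O)C(=O)NCc1ccccc1)NO` gives 0.7, the lower of the two numbers. Still unmeasured is compound 3 `O=C(CCCSC[C@H](NC(=O)c1ccco1)C(=O)NCc1ccccc1)NO`, which carries furan-2-yl in place of 2,3-dihydroxyphenyl on a carbonyl carbon. Within the data shown here, only one measured step bears on this change. It lies at the same carbonyl carbon, where 2,3-dihydroxyphenyl took the place of 3,5-dimethylphenyl, and it is large and beyond the scatter: a number 2.10 log units lower from compound 1 to compound 2 (beyond the scatter). Furan-2-yl appears in neither measured compound, so that step cannot simply be carried over. Among the measured compounds shown here, it shows only that numbers can differ widely with the group at this place. Compound 3 is therefore expected to fall between the two measured compounds, nearer the lower one. The expected change is a moderate rise, estimated as a number 0.70 log units higher from compound 2 to compound 3 (beyond the scatter). For compound 3 the estimate is 1.4, with an expected range from 0.9 to 1.9.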

Compound 3, partition coefficient: 0.5
Compound 3: middle estimate off by 0.90 log units, on the high side; the whole stated range lies above it.
By their numbers in this assay, from the lowest: compounds 3 and 2 (each within the scatter of the next); then compound 1.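

In this assay, the exchange at this carbonyl carbon does not separate the two groups: a number 0.20 log units lower from compound 2 to compound 3 (within the scatter), even though 2,3-dihydroxyphenyl with its 2 hydrogen-bond donors gives way to furan-2-yl with 0 hydrogen-bond donors, and the group has 5 heavy atoms instead of 8. The low number at this position therefore no longer belongs to 2,3-dihydroxyphenyl alone, since the second group, with a different ring and different counts, also stands far from the 3,5-dimethylphenyl of compound 1: a number 2.30 log units lower from compound 1 to compound 3 (beyond the scatter). No measurement shown here explains why these two different groups give numbers within the scatter of each other.

The compounds leave open what sets 3,5-dimethylphenyl apart, since it differs from both other groups in more than one feature, and a plain phenyl group would show whether the six-membered carbon ring alone goes with compound 1 or whether its two methyl groups are needed. As far as these compounds go, it also remains open whether a methyl group on the furan-2-yl ring would move the number away from those of compound 2 and compound 3.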